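Shortening the nitrate-bearing ester chain of compound 2

The compounds below may be only part of what the source reports. "The series", "measured", "known", "first", "only" and "open" are said of these compounds alone.

Compound 1 `CC1=C(C(=O)OCCO[N+](=O)[O-])[C@@H](c2cccc3nonc23)C([N+](=O)[O-])=C(C)C1`: 115 nM
Compound 2 `CC1=C(C(=O)OCCCCO[N+](=O)[O-])C(c2cccc3nonc23)C([N+](=O)[O-])=C(C)C1`: 878 nM
Compound 3 `CC1=C(C(=O)O[C@H](C)CO[N+](=O)[O-])[C@@H](c2cccc3nonc23)C([N+](=O)[O-])=C(C)C1`: 59.6 nM

All three were tested in a functional assay (ileum) for antagonist activity, with Cavia porcellus as the target; on this read-out lower numbers stand for stronger inhibition and higher numbers for weaker inhibition. Compound 2 gives the highest number of the three; compound 1 is nearest to it and compound 3 furthest, both gaps beyond the scatter. Going by the values given here, the single step measured in one place, a 1.9-fold lower number from compound 1 to compound 3 (0.29 log units; within the scatter), does not touch the ester chain. Compound 4 `CC1=C(C(=O)OCCCO[N+](=O)[O-])C(c2cccc3nonc23)C([N+](=O)[O-])=C(C)C1` differs from compound 2 by nitrooxy in place of (nitrooxy)methyl on a saturated chain carbon, three bonds along the chain from an oxygen next to a carbonyl group. Among the compounds with values here, no measured step bears directly on this change; the values of compound 1 and compound 2 show that the 2-(nitrooxy)ethyl chain gives the lower number, and compound 4 carries the 3-(nitrooxy)propyl chain that stands between those two. Compound 4 is therefore expected to fall between them, at 320 nM (range 110 nM to 900 nM), an expected step of a 2.7-fold lower number from compound 2 to compound 4 (0.44 log units; beyond the scatter).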

Compound 4, half-maximal inhibitory concentration: 241 nM
For compound 4 the middle estimate is 1.3-fold (0.12 log units) above the measured one, and the stated range covers the measured number.
By their numbers in this assay, from the lowest: compounds 3 and 1 (each within the scatter of the next); then compound 4; then compound 2.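

Shortening the ester chain from 4-(nitrooxy)butyl to 3-(nitrooxy)propyl gives a 3.6-fold lower number from compound 2 to compound 4 (0.56 log units; beyond the scatter) and is the first step measured on the chain itself. Chain length alone therefore moves the number here by more than the usual scatter, with the rest of the molecule unchanged. Going by these compounds, it remains open how a chain longer than 4-(nitrooxy)butyl, or one ending in a hydroxyl group or a carboxylic acid instead of nitrooxy, would compare. Nothing in the data shown explains why the shorter chain gives the lower number.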